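Swapping an aromatic ring for cyclohexyl on the amine nitrogen

The source may report more compounds than this note shows. Statements on the series, on what has been measured and on what is new or still open speak of the compounds shown alone.

Measured compounds:
- compound 1, `COc1ccc(N/C(CCNC2=CC(=O)c3ccccc3C2=O)=N\S(=O)(=O)c2ccc(C)cc2)cc1OC`: 60600 nM
- compound 2, `Cc1ccc(S(=O)(=O)/N=C(/CCNC2=CC(=O)c3ccccc3C2=O)Nc2ccc(F)c(F)c2)cc1`: 55200 nM
- compound 3, `Cc1ccc(S(=O)(=O)/N=C(/CCNC2=CC(=O)c3ccccc3C2=O)Nc2ccc(Cl)cc2Cl)cc1`: 41900 nM

These three compounds share one core and differ only in the group on the amine nitrogen. In an ADME assay on HEK293 cells (Homo sapiens) for cytotoxicity, read by MTT assay, with a stated time of 48 h (a higher number here means a weaker inhibitor, a lower number a stronger inhibitor), compound 3 gives the lowest of the three numbers, but its distance to the others is small: a 1.3-fold lower number from compound 2 to compound 3 (0.12 log units; within the scatter) and a 1.4-fold lower number from compound 1 to compound 3 (0.16 log units; within the scatter) both fall within the scatter, so the three compounds cannot be told apart on this assay.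

Compound 4, `Cc1ccc(S(=O)(=O)/N=C(/CCNC2=CC(=O)c3ccccc3C2=O)NC2CCCCC2)cc1`, is not yet measured. It differs from compound 3 in one place: cyclohexyl in place of 2,4-dichlorophenyl on an amine nitrogen. Among the measured compounds shown here, none of the measured steps swaps the aromatic ring for a non-aromatic one; the steps of a 1.1-fold lower number from compound 1 to compound 2 (0.04 log units; within the scatter), a 1.4-fold lower number from compound 1 to compound 3 (0.16 log units; within the scatter) and a 1.3-fold lower number from compound 2 to compound 3 (0.12 log units; within the scatter) only exchange substituents on an aromatic ring, and all stayed within the scatter. For the measured compounds named here, with no step that bears directly on this change, and with every measured change leaving the number essentially unmoved, compound 4 is expected to land near compound 3, with a step of a 1.2-fold higher number from compound 3 to compound 4 (0.08 log units; within the scatter), which is not beyond the scatter. The estimated value for compound 4 in this assay is 50000 nM, within a range from 22000 nM to 110000 nM.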

Compound 4, half-maximal inhibitory concentration: 50100 nM
Compound 4: the middle estimate sits 1.0-fold (0.00 log units) below what was measured; the range from low to high includes it.
By their numbers in this assay, from the lowest: compounds 3, 4, 2 and 1 (each within the scatter of the next).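

Cyclohexyl on the amine nitrogen replaces the aromatic ring itself, not just the substituents on it, and the number in this assay does not move beyond the scatter: the steps are a 1.2-fold higher number from compound 3 to compound 4 (0.08 log units; within the scatter) and a 1.1-fold lower number from compound 2 to compound 4 (0.04 log units; within the scatter) and a 1.2-fold lower number from compound 1 to compound 4 (0.08 log units; within the scatter) in turn. The earlier compounds shown here showed this insensitivity only among substituted phenyl rings, whereas compound 4 extends it to a six-membered non-aromatic ring of carbon only, so across these four compounds an aromatic ring at this position makes no readable difference to the number. No measurement here accounts for this result.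

The compounds shown leave open whether a group of another kind on this nitrogen, such as a longer alkyl chain or a chain ending in a carboxylic acid or an amine, would shift the number beyond the scatter. All four groups are six-membered carbon rings, so a smaller group such as methyl also remains an open case.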